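The source may report more compounds than this note shows. Statements on the series, on what has been measured and on what is new or still open speak of the compounds shown alone.

Measured in a functional assay on A549 cells (Homo sapiens) for antiproliferative activity, read by MTT assay, with a stated time of 72 h; a higher number here means a weaker inhibitor, a lower number a stronger inhibitor:
- Compound 1 `CCN(CC)CCCn1cccc1/C=N/NC(=O)Nc1ccc(Oc2ccnc3[nH]ccc23)c(F)c1`: 1210 nM
- Compound 2 `O=C(N/N=C/c1cccn1CCCN1CCCCC1)Nc1ccc(Oc2ccnc3[nH]ccc23)c(F)c1`: 2850 nM

Of these two, compound 2 has the higher number and is therefore the weaker inhibitor. Going by the values given here, the only measured step is a 2.4-fold higher number from compound 1 to compound 2 (0.37 log units; beyond the scatter), a modest change that comes with piperidin-1-yl in place of diethylamino.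

Compound 3 `O=C(N/N=C/c1cccn1CCCN1CCCC1)Nc1ccc(Oc2ccnc3[nH]ccc23)c(F)c1` has not yet been measured. Its difference from compound 2 is pyrrolidin-1-yl in place of piperidin-1-yl on a saturated chain carbon, three bonds along the chain from an aromatic nitrogen. This change sits on a saturated chain carbon, three bonds along the chain from an aromatic nitrogen, the same place as in the measured step. Among the compounds with values here, that single step is a thin guide, and no measured compound carries pyrrolidin-1-yl. Compound 1, which also lacks piperidin-1-yl, gives 1210 nM, so a small move to a lower number in this assay is expected, perhaps none beyond the scatter.

The expected step is a 1.5-fold lower number from compound 2 to compound 3 (0.18 log units; within the scatter). For compound 3 the estimated value is 1900 nM, with an expected range of 850 nM to 4000 nM.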

Compound 3, half-maximal inhibitory concentration: 2010 nM
The estimate for compound 3 lay 1.1-fold (0.02 log units) below the measured number, and the stated range covers the measured number.
By their numbers in this assay, from the lowest: compounds 1, 3 and 2 (each within the scatter of the next, the first and the last beyond it).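

In this assay, pyrrolidin-1-yl in place of piperidin-1-yl gives a 1.4-fold lower number from compound 2 to compound 3 (0.15 log units; within the scatter), so going from a six-membered to a five-membered ring at this position does not clearly separate these two compounds. Pyrrolidin-1-yl in place of diethylamino gives a 1.7-fold higher number from compound 1 to compound 3 (0.22 log units; within the scatter), so compound 3 cannot be told apart from compound 1 either, although compound 1 and compound 2 differ by more than the scatter; its intermediate value blurs the modest gap seen earlier rather than adding a clear ranking of the three amine groups. Nothing available here accounts for these results at the molecular level.

The compounds shown leave open whether a morpholin-4-yl group or a smaller dimethylamino group on this chain would give a number in the same range. They also do not show how a shorter chain carrying pyrrolidin-1-yl would compare.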